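Extending the triazole side chain from compound 3 to compound 4

The source may hold more compounds than are shown below. What is called first, only, known or untested is meant among the compounds shown, and "the series" means these compounds.

Within the data shown here, compound 3 `Cn1ncnc1-c1cc(Oc2ccc(NC(=O)N/N=C/c3ccccc3)cc2F)ccn1` carries a 1-methyl-1H-1,2,4-triazol-5-yl group on its core, and in a functional assay on MKN-45 cells (Homo sapiens) for cytotoxicity, read by MTT assay, with a stated time of 72 h (on this read-out higher numbers stand for weaker inhibition and lower numbers for stronger inhibition), compound 3 gives only a limit of > 100000 nM, not a number; it is the one compound that sits at the assay limit (the limit of > 100000 nM in this assay, at which 1 of the 3 values shown sits). Compound 4 `CN(C)CCn1cnnc1-c1cc(Oc2ccc(NC(=O)N/N=C/c3ccccc3)cc2F)ccn1` differs from it in one place (4-(2-(dimethylamino)ethyl)-4H-1,2,4-triazol-3-yl in place of 1-methyl-1H-1,2,4-triazol-5-yl on an aromatic carbon). Compound 1 `CN(C)CCn1cnnc1-c1cc(Oc2ccc(NC(=O)N/N=C/c3c(O)ccc4ccccc34)cc2F)ccn1` and compound 2 `COc1ccc(/C=N/NC(=O)Nc2ccc(Oc3ccnc(-c4nncn4CCN(C)C)c3)c(F)c2)c(OC)c1` already carry this longer group; compound 1 gives 2020 nM and compound 2 gives 1680 nM in this assay. Among the measured compounds shown here, the only measured step, a 1.2-fold lower number from compound 1 to compound 2 (0.08 log units; within the scatter), changes a different part of the molecule and does not bear on the triazole change; no measured pair shows the change itself. Compound 4 is therefore expected at 8000 nM, between 1500 nM and 100000 nM, with the step of an at least 12-fold lower number from compound 3 to compound 4 (1.09 log units; beyond the scatter) from the limit uncertain in size.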

Compound 4, half-maximal inhibitory concentration: 2730 nM
Compound 4: the middle estimate sits 2.9-fold (0.47 log units) above what was measured; the measured number falls inside the stated range.
By their numbers in this assay, from the lowest: compounds 2, 1 and 4 (each within the scatter of the next). At a limit, above all of these: compound 3.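

The change of 1-methyl-1H-1,2,4-triazol-5-yl to 4-(2-(dimethylamino)ethyl)-4H-1,2,4-triazol-3-yl is now measured directly, giving an at least 36-fold lower number from compound 3 to compound 4 (1.56 log units; beyond the scatter). Its size is only a bound, as compound 3 stands at a limit and not at a number: the limit of > 100000 nM in this assay, at which 1 of the 4 values shown sits. With this longer group present, phenyl shows no readable difference from the two larger groups in this assay, with a 1.6-fold higher number from compound 2 to compound 4 (0.21 log units; within the scatter) and a 1.4-fold higher number from compound 1 to compound 4 (0.13 log units; within the scatter).

The compounds shown leave open whether the terminal dimethylamino group is needed, or whether a morpholine or a hydroxyl in its place would serve as well. They also do not separate the chain from the different triazole attachment that comes with it.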